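The source may hold more compounds than are shown below. What is called first, only, known or untested is meant among the compounds shown, and "the series" means these compounds.

Compound 1 `Cn1cnc2c(Nc3ccccc3)ncnc21` was tested in an assay on isolated protein for inhibition of Rho-associated protein kinase 1 (Homo sapiens), tested at 30 uM (on this read-out higher numbers stand for more inhibition at the one concentration tested (going by the name of the read-out) and lower numbers for less inhibition), where compound 1 gives 0%. Compound 2 `Cn1cnc2c(Nc3ccc(F)cc3)ncnc21` carries one change relative to compound 1, (fluoro in place of hydrogen on an aromatic carbon), and in this assay compound 2 gives 7%. The resulting step of a number 7 percentage points higher from compound 1 to compound 2 (within the scatter) is a small one. Compound 3 `Cn1cnc2c(Sc3ccccc3)ncnc21` differs from compound 1 in its core; the difference between the two cores is not broken down here. In this assay compound 3 gives 6%, a number that sits close to those of compound 1 and compound 2 alike. Compound 4 `Cn1cnc2c(Sc3ccc(F)cc3)ncnc21` has not yet been measured. It differs from compound 3 by fluoro in place of hydrogen on an aromatic carbon, the same change that turns compound 1 into compound 2, at a place described in exactly the same words. Set beside the earlier step of a number 7 percentage points higher from compound 1 to compound 2 (within the scatter), the step of a number 4 percentage points higher from compound 3 to compound 4 (within the scatter) is expected to be similarly small. For the measured compounds named here, that expectation rests on the one earlier example alone. Compound 4 is therefore estimated at 10%, with a range from 0% to 25%, pending the actual measurement.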

Compound 4, a percentage reported as inhibition, at one concentration (the size of the read-out at that concentration, not a potency): 6%
Estimate against measurement, compound 4: 4 percentage points above; low and high end bracket the measured number.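

In this assay, putting fluoro in place of hydrogen on an aromatic carbon gives no change at the digits printed from compound 3 to compound 4 (within the scatter), a step as small as the one seen for the same change on the other core. Within what this read-out can resolve, the change therefore behaves alike on both cores: the same change on two cores in this assay, a number 7 percentage points higher (within the scatter) from compound 1 to compound 2 and no change at the digits printed (within the scatter) from compound 3 to compound 4, 7 percentage points apart, within the scatter of two such steps

For the compounds shown here, this does not show that fluoro has no effect or that its effect is truly the same on both cores, since only two pairs are available and all four numbers are small, so any modest difference could be hidden in the scatter. The compounds shown leave open whether another group at the same place, such as methoxy, an amine or a carboxylic acid, would lift the number clear of the scatter on either core. They also leave open whether fluoro would behave the same way on a compound that already inhibits strongly.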